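Ethyl to phenoxy in the sulfonamide series

A few compounds are considered here, and "the series" means these few. Any claim that something is new, unique, unknown or untested is made for them only; others in the source may bear on it.

Of the compounds shown here, two have been measured so far in a functional assay on MCF7 cells (Homo sapiens) for antiproliferative activity, read by sulforhodamine B assay, with a stated time of 48 h; a lower number here means a stronger inhibitor, a higher number a weaker inhibitor. Compound 1 (`O=C1NCCN1c1ccc(S(=O)(=O)Nc2ccc(F)c(F)c2)cc1`) gives 620 nM, and compound 2 (`CCc1cccc(NS(=O)(=O)c2ccc(N3CCNC3=O)cc2)c1`) gives 130 nM, the lower of the two numbers. The next compound, compound 3 (`O=C1NCCN1c1ccc(S(=O)(=O)Nc2cccc(Oc3ccccc3)c2)cc1`), differs from compound 2 by phenoxy in place of ethyl on an aromatic carbon, meta to a large group: phenoxy in place of ethyl on an aromatic carbon.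

Among the compounds with values here, only one measured step bears on this change. With 3-ethylphenyl in place of 3,4-difluorophenyl on a sulfonamide nitrogen, it shows a 4.8-fold lower number from compound 1 to compound 2 (0.68 log units; beyond the scatter). Within the data shown here, that step is modest and concerns the same substituent, but no measured step replaces ethyl, so it gives a rough size and only weak guidance on direction. A step of similar or smaller size is expected here, more likely upward, since compound 2 sits at the lower end with 130 nM. The expected change is a 2.2-fold higher number from compound 2 to compound 3 (0.33 log units; beyond the scatter). The estimated value for compound 3 is 280 nM, with an expected range from 70 nM to 1100 nM.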

Compound 3, half-maximal inhibitory concentration: 220 nM
Beside the measured number, compound 3's estimate is 1.3-fold (0.10 log units) above it; the measured number falls inside the stated range.
By their numbers in this assay, from the lowest: compounds 2 and 3 (each within the scatter of the next); then compound 1.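

In this assay phenoxy in place of ethyl on an aromatic carbon, meta to a large group, gives a 1.7-fold higher number from compound 2 to compound 3 (0.23 log units; within the scatter) and so leaves the two groups unranked in this series. Within the data shown here, this is the first measured replacement of ethyl at this position, and it shows that a group of 7 heavy atoms, carrying one six-membered aromatic ring and 1 hydrogen-bond acceptor, can stand where ethyl's 2 heavy atoms stood without a step beyond the scatter. No measured evidence accounts for this match between the two groups.

Still open, as far as these compounds go, is how either group compares with plain hydrogen, an amine or a carboxylic acid on the same aromatic carbon, which would show whether this position responds to the group placed there at all. Also open, from the compounds shown here alone, is whether a chlorine atom or a methoxy group on the phenoxy ring, or a longer chain such as benzyloxy in its place, would keep the number in the same range or move it beyond the scatter.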